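The source may hold more compounds than are shown below. What is called first, only, known or untested is meant among the compounds shown, and "the series" means these compounds.

Of the compounds shown here, three have so far been measured in an assay on isolated protein for binding affinity to leukotriene B4 receptor 1 (Homo sapiens), tested at 1 uM; a higher number here means more inhibition at the concentration tested (going by the name of the read-out), a lower number less inhibition. Compound 1 `CCc1cc(C(C)=O)c(O)cc1OCCCCCCCC(C)(C)C#N` gives 29%, the highest of the three numbers. Compound 3 `C=CCc1cc(C(C)=O)c(O)cc1OCCCCCC(=O)NO` gives 28%, which lies within the scatter of compound 1, while compound 2 `C=CCc1cc(C(C)=O)c(O)cc1OCCCCCC` gives 9%, beyond the scatter below it. Compound 4 `CCc1cc(C(C)=O)c(O)cc1OCCCCCCc1nnn[nH]1` is not yet measured; it differs from compound 1 by 1H-tetrazol-5-yl in place of 2-cyano-2-methylpropyl on a saturated chain carbon, six bonds along the chain from an oxygen on an aromatic ring. Among the measured compounds shown here, the one measured step that speaks to this kind of change is a number 19 percentage points higher from compound 2 to compound 3 (beyond the scatter), where a group rich in hydrogen-bond donors and acceptors replaced a plain chain methyl. The tetrazole entering compound 4 brings such donors and acceptors too, so a modest rise is expected, a number 9 percentage points higher from compound 1 to compound 4 (within the scatter). Compound 4 is therefore estimated at 38%, in a range from 22% to 55%.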

Compound 4, a percentage reported as inhibition, at one concentration (the size of the read-out at that concentration, not a potency): 60%
For compound 4 the middle estimate is 22 percentage points below the measured one; the measured number lies above the stated range.
By their numbers in this assay, from the lowest: compound 2; then compounds 3 and 1 (each within the scatter of the next); then compound 4.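

In this assay, the group at the end of the chain, six bonds along from the oxygen on the aromatic ring, strongly affects the read-out: 1H-tetrazol-5-yl in place of 2-cyano-2-methylpropyl gives a number 31 percentage points higher from compound 1 to compound 4 (beyond the scatter), a large step. Among the compounds shown, only this chain end carries a five-membered aromatic ring. Nothing available here explains the gain.

As far as these compounds go, whether a carboxylic acid at the same chain end would match the tetrazole remains open. So does how a longer chain carrying the tetrazole would behave, and a reading at one concentration gives no potency.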